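Swapping the tail ring of compound 2: piperazine to piperidine

This account rests on a few compounds, and the source may have more. Where it says the series, first, only, none or still open, it means among the compounds named here.

Measured so far:
compound 1, `COc1cc2c(Oc3ccc(NC(=O)c4nn(-c5ccccc5F)c(=O)c5ccccc45)cc3F)ccnc2cc1OCCCN1CCN(C)CC1`: 480 nM
compound 2, `COc1cc2c(Oc3ccc(NC(=O)c4nn(-c5ccccc5Br)c(=O)c5ccccc45)cc3F)ccnc2cc1OCCCN1CCN(C)CC1`: 1190 nM

Both were tested in a functional assay on HT-29 cells (Homo sapiens) for cytotoxicity, read by MTT assay, with a stated time of 72 h; on this read-out higher numbers stand for weaker inhibition and lower numbers for stronger inhibition. Compound 2 gives the highest of the two numbers, and its nearest neighbour is compound 1, which differs only by the halogen on the outer aromatic ring; that step, a 2.5-fold higher number from compound 1 to compound 2 (0.39 log units; beyond the scatter), is modest but beyond the scatter.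

Compound 3, `COc1cc2c(Oc3ccc(NC(=O)c4nn(-c5ccccc5Br)c(=O)c5ccccc45)cc3F)ccnc2cc1OCCCN1CCC(C)CC1`, differs from compound 2 elsewhere: 4-methylpiperidin-1-yl in place of 4-methylpiperazin-1-yl on a saturated chain carbon, three bonds along the chain from an oxygen on an aromatic ring. No measured step touches this part of the molecule, so the one step shown, from a fluoro to a bromo substituent, says nothing about it. With no guidance from the data, the expectation is a step within the scatter, perhaps a slight weakening: compound 3 is estimated at 1600 nM, with a likely range of 600 nM to 4500 nM, which means an expected step of a 1.3-fold higher number from compound 2 to compound 3 (0.13 log units; within the scatter).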

Compound 3, half-maximal inhibitory concentration: 950 nM
The estimate for compound 3 lay 1.7-fold (0.23 log units) above the measured number; low and high end bracket the measured number.
By their numbers in this assay, from the lowest: compounds 1, 3 and 2 (each within the scatter of the next, the first and the last beyond it).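

In this assay, 4-methylpiperidin-1-yl in place of 4-methylpiperazin-1-yl at the end of the propyl chain gives a 1.3-fold lower number from compound 2 to compound 3 (0.10 log units; within the scatter), so this pair cannot be told apart on this read-out. Among these compounds, this is the first view of the tail, since the earlier step changed only the halogen on the outer aromatic ring, and it shows that, with bromo present, the ring with 1 hetero atom reads like the ring with 2 hetero atoms. Nothing measured here offers a reason for this result.

On these data alone, it remains open whether the same swap would read alike with the fluoro group of compound 1 in place of bromo. As far as these compounds go, how a morpholine ring, a dimethylamino group or a longer chain would read at this place also remains open.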